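A few compounds are considered here, and "the series" means these few. Any claim that something is new, unique, unknown or untested is made for them only; others in the source may bear on it.

Compound 3 `O=C1Cc2cc(S(=O)(=O)N3CCN(c4ccc(Cl)cc4)CC3)ccc2N1` sits at the weak end of the numbers gathered so far. In an assay on isolated protein for inhibition of lysosomal alpha-glucosidase (Homo sapiens), read by fluorescence, with stated times of 5 min and 45 min (a lower number here means a stronger inhibitor, a higher number a weaker inhibitor), compound 3 gives 94300 nM. Within the data shown here, its nearest neighbour, compound 1 `O=C1Cc2cc(S(=O)(=O)N3CCN(c4ccc(O)cc4)CC3)ccc2N1`, carries a hydroxy in place of the chloro and gives 1880 nM in this assay, so that the single step of a 50-fold higher number from compound 1 to compound 3 (1.70 log units; beyond the scatter) is the only one that can be put in numbers. Compound 2 `O=C1Cc2cc(S(=O)(=O)N3CCN(c4ccc(F)cc4)CC3)ccc2N1`, with a fluoro at the same position, is recorded in this assay as "not active" (no number reported), with no number attached.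

The next compound, compound 4 `O=C1Cc2cc(S(=O)(=O)N3CCN(c4ccc(CO)cc4)CC3)ccc2N1`, changes compound 3 in one place: hydroxymethyl in place of chloro on an aromatic carbon. Among the measured compounds shown here, the only measured step that bears on this change is the one from compound 1 to compound 3, which was large and ran toward the weaker side when a hydroxy became a chloro. Because the measured step of a 50-fold higher number from compound 1 to compound 3 (1.70 log units; beyond the scatter) shows a move to the weaker side when a hydroxy became a chloro, and the hydroxymethyl of compound 4 brings back a hydrogen-bond donor and a hydrogen-bond acceptor that the chloro of compound 3 lacks, the step is expected to run the other way; a return toward compound 1 is expected, though it need not reach that level, since no hydroxymethyl has yet been measured. Compound 4 is therefore estimated to give 6000 nM in this assay, between 1200 nM and 30000 nM, an expected step of a 16-fold lower number from compound 3 to compound 4 (1.20 log units; beyond the scatter).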

Compound 4, half-maximal inhibitory concentration: 13000 nM
Beside the measured number, compound 4's estimate is 2.2-fold (0.34 log units) below it; the measured number falls inside the stated range.
By their numbers in this assay, from the lowest: compound 1; then compound 4; then compound 3.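

In this assay the change from 4-chlorophenyl to 4-(hydroxymethyl)phenyl gives a 7.3-fold lower number from compound 3 to compound 4 (0.86 log units; beyond the scatter) and so shows that the weak level of the chloro compound can be left with a group other than hydroxy at this position. The recovery is only partial, however: the step of a 6.9-fold higher number from compound 1 to compound 4 (0.84 log units; beyond the scatter) sets hydroxymethyl apart from hydroxy, so this position distinguishes between two oxygen-bearing groups and does not respond to the presence of oxygen alone. The order of the three numbers, with hydroxy lowest, hydroxymethyl in the middle and chloro highest, is thus established for these compounds, but no measurement at hand accounts for it.

Going by these compounds, whether an amine, a carboxylic acid or a longer chain such as hydroxyethyl would fall within that order remains open, and steps involving compound 2, with its fluoro and no number, cannot be read. The compounds shown also leave open whether the hydroxymethyl change would give a step of similar size elsewhere on the ring or on a different core.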